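Replacing cyano with trifluoromethyl on the arenesulfonyl series

A few compounds are considered here, and "the series" means these few. Any claim that something is new, unique, unknown or untested is made for them only; others in the source may bear on it.

In a functional assay on HeLa cells (Homo sapiens) for inhibition, read by sulforhodamine B assay, with a stated time of 74 h (a lower number here means a stronger inhibitor, a higher number a weaker inhibitor), compound 1 (`O=C1C=CC2(C=C1)OCC(=O)N2S(=O)(=O)c1ccccc1`) gives > 10000 nM, which is a limit of the assay and not a number. Among the compounds with values here, compound 2 (`N#Cc1cccc(S(=O)(=O)N2C(=O)COC23C=CC(=O)C=C3)c1`) gives 180 nM, the only true number so far. Within the data shown here, the one measured step is an at least 55-fold lower number from compound 1 to compound 2 (1.74 log units; beyond the scatter). Among the measured compounds shown here, that step compares cyano with hydrogen, so it bears on the next change only indirectly, and no measurement yet compares cyano with trifluoromethyl. Compound 3 (`O=C1C=CC2(C=C1)OCC(=O)N2S(=O)(=O)c1cccc(C(F)(F)F)c1`) keeps the shared core and carries trifluoromethyl in place of cyano on an aromatic carbon. The substituent position stays occupied, so most of the gain seen in an at least 55-fold lower number from compound 1 to compound 2 (1.74 log units; beyond the scatter) is expected to persist, with a slightly higher number in this assay but no change beyond the scatter. The estimated step is a 1.7-fold higher number from compound 2 to compound 3 (0.22 log units; within the scatter). For compound 3 the expected value is 300 nM, with an estimated range of 70 nM to 1500 nM.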

Compound 3, half-maximal inhibitory concentration: 570 nM
The estimate for compound 3 lay 1.9-fold (0.28 log units) below the measured number, and the stated range covers the measured number.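

In this assay, this aromatic carbon does not merely need to be occupied: the identity of the substituent matters, with a 3.2-fold higher number from compound 2 to compound 3 (0.50 log units; beyond the scatter). The earlier compounds shown here compared cyano only with hydrogen and could not show that two substituents at this place would separate. Trifluoromethyl also stands clear of hydrogen, with an at least 17-fold lower number from compound 1 to compound 3 (1.24 log units; beyond the scatter), so the gain is not confined to cyano, but its full size cannot be read because compound 1 stands at a limit of the assay and not at a number: the limit of > 10000 nM in this assay, at which 1 of the 3 values shown sits.

The compounds shown leave open whether an amine, a carboxylic acid or a methoxy group at this carbon would track with cyano, with trifluoromethyl or with neither. Also open, going by these compounds, is whether the order of cyano and trifluoromethyl holds on another carbon of the ring or in another cell line.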